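The source may report more compounds than this note shows. Statements on the series, on what has been measured and on what is new or still open speak of the compounds shown alone.

Compounds measured in an assay on isolated protein for inhibition of histone deacetylase 4 (Homo sapiens), tested at 1 uM; on this read-out lower numbers stand for less inhibition and higher numbers for more inhibition at the one concentration tested (going by the name of the read-out):
compound 1, `CC(C)[C@@H](C(=O)Nc1ccc(C(=O)Nc2ccccc2N)cc1)c1ccccc1`, 9%;
compound 2, `CC(C)[C@@H](C(=O)Nc1ccc(C(=O)Nc2ccc(F)cc2N)cc1)c1ccccc1`, 0%.

Compound 2 stands lowest of the two numbers in this assay; its nearest neighbour is compound 1, and the step of a number 9 percentage points lower from compound 1 to compound 2 (within the scatter) lies within the scatter, so the two cannot be told apart. Compound 3, `Nc1cc(F)ccc1NC(=O)c1ccc(NC(=O)C2CC2c2ccccc2)cc1`, differs from compound 2 in one place: 2-phenylcyclopropyl in place of 2-methyl-1-phenylpropyl on a carbonyl carbon. Among the measured compounds shown here, no measured step touches this change; the only step on record exchanges fluoro for hydrogen elsewhere. Both measured compounds give low inhibition, so compound 3 is expected to show no step beyond the scatter, a number 5 percentage points higher from compound 2 to compound 3 (within the scatter). The estimate for compound 3 is 5%, ranging from 0% to 20%.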

Compound 3, a percentage reported as inhibition, at one concentration (the size of the read-out at that concentration, not a potency): 0%
Estimate against measurement, compound 3: 5 percentage points above, and the stated range covers the measured number.
By their numbers in this assay, from the lowest: compounds 2, 3 and 1 (each within the scatter of the next).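

In this assay, the first change read at the group on the carbonyl carbon, 2-phenylcyclopropyl in place of 2-methyl-1-phenylpropyl, gives a step (no change at the digits printed from compound 2 to compound 3 (within the scatter)) that leaves compound 2 and compound 3 indistinguishable. The earlier step concerned only fluoro in place of hydrogen, so this one shows that the same low reading also holds with a three-membered ring in this group. No measurement bears on why these two compounds cannot be told apart. The compounds shown leave open whether an amine or a carboxylic acid on this carbonyl carbon would raise inhibition beyond the scatter.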